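The source may hold more compounds than are shown below. What is called first, only, known or untested is meant among the compounds shown, and "the series" means these compounds.

Measured in a functional assay on NCI-H460 cells (Homo sapiens) for inhibition, read by MTT assay, with a stated time of 72 h (a higher number here means a weaker inhibitor, a lower number a stronger inhibitor), so far:
- compound 1 `COc1cc(NC(C)CCCNC(=O)Nc2cccc(Cl)c2)c2ncccc2c1` gives 37000 nM
- compound 2 `COc1cc(NC(C)CCCNC(=O)Nc2ccc(F)cc2)c2ncccc2c1` gives 26000 nM
- compound 3 `COc1cc(NC(C)CCCNC(=O)NNC(=O)Nc2cccc(F)c2)c2ncccc2c1` gives 50000 nM

Compound 3 is not separated from either of the others: the steps to it are (a 1.4-fold higher number from compound 1 to compound 3 (0.13 log units; within the scatter)) and (a 1.9-fold higher number from compound 2 to compound 3 (0.28 log units; within the scatter)). The next compound, compound 4 `COc1cc(NC(C)CCCNC(=O)Nc2ccc(C(F)(F)F)cc2)c2ncccc2c1`, is still unmeasured. The change is 4-(trifluoromethyl)phenyl in place of ((3-fluorophenyl)carbamoyl)amino on an amide-type nitrogen, with 4-(trifluoromethyl)phenyl in place of ((3-fluorophenyl)carbamoyl)amino on an amide-type nitrogen. Compound 4 therefore carries a substituted phenyl group on that nitrogen, as compound 1 and compound 2 do. The two steps to compound 3 are the nearest measured counterparts of this change, taken in the opposite sense, and neither leaves the scatter. The exchange of one phenyl group for another (a 1.4-fold lower number from compound 1 to compound 2 (0.15 log units; within the scatter)) also stays within it. Going by the values given here, no measured compound carries 4-(trifluoromethyl)phenyl, so that group remains untested. No step beyond the scatter is therefore expected in this assay, and the expected step is (a 1.8-fold lower number from compound 3 to compound 4 (0.25 log units; within the scatter)). The estimate for compound 4 is 28000 nM with an expected range of 10000 nM to 60000 nM in this series.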

Compound 4, half-maximal inhibitory concentration: 24000 nM
Estimate against measurement, compound 4: 1.2-fold (0.07 log units) above; the measured number falls inside the stated range.
By their numbers in this assay, from the lowest: compounds 4, 2, 1 and 3 (each within the scatter of the next, the first and the last beyond it).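

In this assay, exchanging the group on the amide-type nitrogen now gives a step beyond the scatter, though a modest one (a 2.1-fold lower number from compound 3 to compound 4 (0.32 log units; beyond the scatter)), as 4-(trifluoromethyl)phenyl replaces ((3-fluorophenyl)carbamoyl)amino. Among the phenyl groups on that nitrogen, the new compound is not separated from the others, either for trifluoromethyl in place of fluoro on an aromatic carbon (a 1.1-fold lower number from compound 2 to compound 4 (0.03 log units; within the scatter)) or for 4-(trifluoromethyl)phenyl in place of 3-chlorophenyl (a 1.5-fold lower number from compound 1 to compound 4 (0.19 log units; within the scatter)). Nothing available gives a reason for the step from compound 3.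

Still open, on these data alone, is whether any group at this nitrogen gives a larger step, such as a phenyl ring carrying a carboxylic acid or a dimethylamino group, or a cyclohexyl ring in place of phenyl. Also open, as far as these compounds go, is how a longer chain linking the shared core to the carbonyl would read here.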